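Dichlorophenyl in place of dimethoxyphenyl: expected cytotoxicity

The compounds below may be only part of what the source reports. "The series", "measured", "known", "first", "only" and "open" are said of these compounds alone.

Measured compounds:
compound 1 `COc1ccc(/C=C/C(=O)c2ccccc2NC(=O)NS(=O)(=O)c2ccc(C)cc2)c(OC)c1`, in an ADME assay on the whole organism for cytotoxicity, with Artemia salina as the target, with a stated time of 24 h (a lower number here means that less compound is needed, a higher number that more compound is needed for the effect), compound 1 gives 16 ug/mL
compound 2 `CCc1cc(/C=C/C(=O)c2ccccc2NC(=O)NS(=O)(=O)c2ccc(C)cc2)cc(OC)c1OC`, compound 2 gives 19.2 ug/mL
compound 3 `Cc1ccc(S(=O)(=O)NC(=O)Nc2ccccc2C(=O)/C=C/c2cccc(F)c2)cc1`, compound 3 gives 4.13 ug/mL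

Compound 1 stands second highest of the three numbers in this assay. Its nearest neighbour is compound 2, reached by a 1.2-fold higher number from compound 1 to compound 2 (0.08 log units; within the scatter). Furthest away is compound 3, reached by a 3.9-fold lower number from compound 1 to compound 3 (0.59 log units; beyond the scatter), and the pair from compound 2 to compound 3 shows a 4.6-fold lower number from compound 2 to compound 3 (0.67 log units; beyond the scatter).

Compound 4 `Cc1ccc(S(=O)(=O)NC(=O)Nc2ccccc2C(=O)/C=C/c2ccc(Cl)cc2Cl)cc1` has not yet been measured. It differs from compound 1 in this way: 2,4-dichlorophenyl in place of 2,4-dimethoxyphenyl on a double-bonded chain carbon bound to a double-bonded chain carbon. Within the data shown here, the step that bears on it is the one from compound 1 to compound 3, where the same 2,4-dimethoxyphenyl was exchanged for a different aryl group and the number moved down. The change to compound 2, which kept methoxy groups, stayed within the scatter. A modest downward step is therefore expected for compound 4, of about a 2.5-fold lower number from compound 1 to compound 4 (0.39 log units; beyond the scatter). Compound 4 is estimated at 6.5 ug/mL, with a range from 2.5 ug/mL to 16 ug/mL.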

Compound 4, concentration for half-maximal effect: 8.34 ug/mL
Beside the measured number, compound 4's estimate is 1.3-fold (0.11 log units) below it; low and high end bracket the measured number.
By their numbers in this assay, from the lowest: compound 3; then compounds 4, 1 and 2 (each within the scatter of the next, the first and the last beyond it).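

Exchanging 2,4-dimethoxyphenyl for 2,4-dichlorophenyl on a double-bonded chain carbon bound to a double-bonded chain carbon gives, in this assay, a 1.9-fold lower number from compound 1 to compound 4 (0.28 log units; within the scatter), so at this place the methoxy groups can be lost without a change that can be read. Carrying halogen does not by itself put an aryl group level with 3-fluorophenyl, as the exchange of that group for 2,4-dichlorophenyl gives a 2.0-fold higher number from compound 3 to compound 4 (0.31 log units; beyond the scatter), while the exchange of 3-ethyl-4,5-dimethoxyphenyl for 2,4-dichlorophenyl gives a 2.3-fold lower number from compound 2 to compound 4 (0.36 log units; beyond the scatter). No measurement is available to explain these differences.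

The compounds shown leave open how a 3-chlorophenyl group would compare with 3-fluorophenyl, and so whether the number follows the kind of halogen or its place on the ring. Also open, on these data alone, is what a phenyl group carrying an amine or a carboxylic acid would give here.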